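Methyl for Isopropyl, Repeated on the Chloro Core

The compounds below may be only part of what the source reports. "The series", "measured", "known", "first", "only" and "open" are said of these compounds alone.

Compound 1 `Cc1ccc(Nc2nc(SCc3cn(CC(=O)NC(=O)Nc4ccccn4)nn3)nc(-c3ccc(Br)cc3)c2C#N)cc1` gives 14400 nM in a functional assay on MCF7 cells (Homo sapiens) for inhibition, read by MTT assay, with a stated time of 72 h; on this read-out higher numbers stand for weaker inhibition and lower numbers for stronger inhibition.
Compound 2 `CC(C)c1ccc(Nc2nc(SCc3cn(CC(=O)NC(=O)Nc4ccccn4)nn3)nc(-c3ccc(Br)cc3)c2C#N)cc1` gives 30600 nM in this assay.
Compound 3 `CC(C)c1ccc(Nc2nc(SCc3cn(CC(=O)NC(=O)Nc4ccccn4)nn3)nc(-c3ccc(Cl)cc3)c2C#N)cc1` gives 39900 nM in this assay.

Of the compounds shown here, three have been measured; compound 4 `Cc1ccc(Nc2nc(SCc3cn(CC(=O)NC(=O)Nc4ccccn4)nn3)nc(-c3ccc(Cl)cc3)c2C#N)cc1` has not. Compound 4 differs from compound 3 in one place: methyl in place of isopropyl on an aromatic carbon. The same change has already been made once among these compounds, from compound 2 to compound 1: methyl in place of isopropyl on an aromatic carbon. In this assay it produced a 2.1-fold lower number from compound 2 to compound 1 (0.33 log units; beyond the scatter). The place of the change is described in the same words for both pairs, so the step to compound 4 is the same change, not merely the same kind.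

The cores on which the two steps are taken differ in one place, as seen from compound 2 to compound 3: chloro in place of bromo on an aromatic carbon. In this assay that difference gave a 1.3-fold higher number from compound 2 to compound 3 (0.12 log units; within the scatter), so the two cores stand close together. Compound 3 holds the highest number of the three measured, though its gap to compound 2 lies within the scatter.

For compound 4 the expected step is a 2.1-fold lower number from compound 3 to compound 4 (0.32 log units; beyond the scatter), because the same change gave a 2.1-fold lower number from compound 2 to compound 1 (0.33 log units; beyond the scatter) on the neighbouring core. Compound 4 is therefore expected to give 19000 nM, with a range from 9000 nM to 40000 nM. The estimate rests on two measured pairs only, and a second core is not enough to call the effect general.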

Compound 4, half-maximal inhibitory concentration: 27000 nM
For compound 4 the middle estimate is 1.4-fold (0.15 log units) below the measured one; the measured number falls inside the stated range.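

In this assay, methyl in place of isopropyl gives a 1.5-fold lower number from compound 3 to compound 4 (0.17 log units; within the scatter), so on the chloro core this step does not stand clear of the scatter by itself, yet it agrees with the step on the bromo core: the same change on two cores in this assay, a 2.1-fold lower number (0.33 log units; beyond the scatter) from compound 2 to compound 1 and a 1.5-fold lower number (0.17 log units; within the scatter) from compound 3 to compound 4, 1.4-fold (0.16 log units) apart, within the scatter of two such steps

The halogen change reads the same way on the pair carrying methyl, where chloro in place of bromo gives a 1.9-fold higher number from compound 1 to compound 4 (0.27 log units; within the scatter), in keeping with the pair carrying isopropyl: the same change on two cores in this assay, a 1.3-fold higher number (0.12 log units; within the scatter) from compound 2 to compound 3 and a 1.9-fold higher number (0.27 log units; within the scatter) from compound 1 to compound 4, 1.4-fold (0.16 log units) apart, within the scatter of two such steps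

Together these pairs show that both changes carried across these two cores without a detectable disagreement, but they do not establish a firm methyl effect on both cores, as only the step on the bromo core lies beyond the scatter, and two cores set no general rule.

The compounds shown leave open whether an ethyl group, a tert-butyl group or a methoxy group on the same aromatic carbon would continue the behaviour seen with methyl and isopropyl. From the compounds shown here alone, it also remains open whether fluoro or trifluoromethyl in place of the halogen, or an amine or a carboxylic acid on either aromatic ring, would give steps that stand clearly beyond the scatter.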